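Notes on a phenoxy-chain series: the bromide end point

This account rests on a few compounds, and the source may have more. Where it says the series, first, only, none or still open, it means among the compounds named here.

Three members measured in a functional assay on ECa-109 cells for inhibition, with ECa-109 cell line (Homo sapiens) as the target, read by MTT assay, with a stated time of 48 h (a higher number here means a weaker inhibitor, a lower number a stronger inhibitor), share the core of compound 1 `COc1ccc(-c2coc3cc(OCCCSC(=S)N4CCN(Cc5ccccc5)CC4)ccc3c2=O)cc1`, which gives 25300 nM. Compound 2 `COc1ccc(-c2coc3cc(OCCCSC(=S)N4CCOCC4)ccc3c2=O)cc1` gives 34000 nM, the highest of the three numbers shown, though both other values lie within the scatter of it. Compound 3 `COc1ccc(-c2coc3cc(OCCCSC(=S)N4CCN(C(C)=O)CC4)ccc3c2=O)cc1` gives 24700 nM. The two measured steps, a 1.0-fold lower number from compound 1 to compound 3 (0.01 log units; within the scatter) and a 1.4-fold lower number from compound 2 to compound 3 (0.14 log units; within the scatter), alter only the ring at the chain end and stay within the scatter. Compound 4 `COc1ccc(-c2coc3cc(OCCBr)ccc3c2=O)cc1` differs from compound 2 by one bromine atom in place of a group of 10 heavy atoms (6 carbon, 1 nitrogen, 1 oxygen, 2 sulfur; one six-membered non-aromatic ring with 2 hetero atoms), on a saturated chain carbon, two bonds along the chain from an oxygen on an aromatic ring. For the measured compounds named here, no measured step touches this change, so the series offers little guide. The expectation for compound 4 is a step of a 1.3-fold higher number from compound 2 to compound 4 (0.12 log units; within the scatter) in this assay, toward a weaker inhibitor if anything. The estimate for compound 4 is 45000 nM, ranging from 15000 nM to 130000 nM.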

Compound 4, half-maximal inhibitory concentration: 55100 nM
For compound 4 the middle estimate is 1.2-fold (0.09 log units) below the measured one; low and high end bracket the measured number.
By their numbers in this assay, from the lowest: compounds 3, 1, 2 and 4 (each within the scatter of the next, the first and the last beyond it).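

In this assay, for the compounds shown here, bromo in place of the whole group of 10 heavy atoms, on a saturated chain carbon, gives a 1.6-fold higher number from compound 2 to compound 4 (0.21 log units; within the scatter), the first step here that removes the ring at the chain end rather than swapping it for another. Even this large change stays within the scatter of compound 2. Nothing available bears on the reason for the size of this step. 

Still open, from the compounds shown here alone, is how a simple amine or a carboxylic acid would read in place of bromo. Also open, going by these compounds, is whether a longer chain ending in bromo would read differently from compound 4.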